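A few compounds are considered here, and "the series" means these few. Any claim that something is new, unique, unknown or untested is made for them only; others in the source may bear on it.

For the measured compounds named here, compound 2 `O=C(Nc1nccs1)c1c(O)c2cccnc2n(-c2ccccc2)c1=O` is one of only two compounds measured in a functional assay on the whole organism for inhibition, with Rattus norvegicus as the target, read by paw edema, at a dose of 100 mg/kg by the oral route; on this read-out higher numbers stand for more inhibition at the one dose given (going by the name of the read-out) and lower numbers for less inhibition. In this assay compound 2 gives 4.6%, and compound 1 `COc1ccccc1NC(=O)c1c(O)c2cccnc2n(-c2ccccc2)c1=O` gives 8.1%, so the two sit within the usual scatter of each other. Going by the values given here, the single measured step that bears on the change ahead is a number 3.5 percentage points lower from compound 1 to compound 2 (within the scatter), which also swapped the group on the amide-type nitrogen. Compound 3 `O=C(NCc1ccncc1)c1c(O)c2cccnc2n(-c2ccccc2)c1=O` has not been measured; it differs from compound 2 by (pyridin-4-yl)methyl in place of 1,3-thiazol-2-yl on an amide-type nitrogen. Because the earlier exchange a number 3.5 percentage points lower from compound 1 to compound 2 (within the scatter) stayed within the scatter, nothing beyond the scatter is expected, a number 1.4 percentage points higher from compound 2 to compound 3 (within the scatter). Compound 3 is therefore estimated at 6%, with a range from -3% to 16%.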

Compound 3, a percentage reported as inhibition, in the whole organism at one dose (the size of the read-out at that dose, not a potency): 10%
For compound 3 the middle estimate is 4 percentage points below the measured one, and the stated range covers the measured number.
By their numbers in this assay, from the lowest: compounds 2, 1 and 3 (each within the scatter of the next).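

Putting (pyridin-4-yl)methyl on the amide-type nitrogen gives, in this assay, a number 5.4 percentage points higher from compound 2 to compound 3 (within the scatter), and a number 1.9 percentage points higher from compound 1 to compound 3 (within the scatter). All three ring-bearing groups at this position therefore lie within the scatter of one another, so the read-out has not yet responded to any exchange here, even with the added step away from the nitrogen's former groups. No measurement is available to explain this.

Still open, from the compounds shown here alone, is whether a group without a ring, such as a longer carbon chain ending in a carboxylic acid or an amine, would move the number beyond the scatter.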